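The compounds below may be only part of what the source reports. "The series", "measured", "known", "first", "only" and "open" are said of these compounds alone.

Compound 1 `CCSc1nnc(-c2ccccc2)n1C`: > 200 mg/kg
Compound 2 `Cn1c(-c2ccccc2F)nnc1S(C)(=O)=O`: > 100 mg/kg

Both compounds were tested in a functional assay on the whole organism for antagonist activity, with Mus musculus as the target; a higher number here means that more compound is needed for the effect, a lower number that less compound is needed. For compound 2, the entry of > 100 mg/kg is a limit and not a number. Compound 1 likewise has only a limit, > 200 mg/kg. Compound 2 therefore offers no measured dose as a starting point.

Compound 3 `CCSc1nnc(-c2ccccc2F)n1C` differs from compound 2 in one place, with ethylsulfanyl in place of methylsulfonyl on an aromatic carbon. This joins the ethylsulfanyl group of compound 1 to the rest of compound 2. Among the measured compounds shown here, no measured step shows what this change does, so any expectation here is tentative, and another limit remains possible. The expected change is an at least 2.0-fold lower number from compound 2 to compound 3 (0.30 log units; that floor lies within the scatter), in the direction of less compound being needed. For compound 3, the estimated dose is 50 mg/kg, with an expected range of 15 mg/kg to 170 mg/kg.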

Compound 3, dose for half-maximal effect: > 200 mg/kg
Compound 3 gave a limit, no number; the forecaster's own chance of this, stated with the estimate: 35%; middle value at least 4.0-fold (0.60 log units) away from the limit.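

In this assay, compound 3 gives > 200 mg/kg, which is a limit and not a number. The steps to compound 3 from compound 1 and from compound 2 therefore cannot be read. The compounds shown leave open what dose any of the three needs, and whether either change alters that dose.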